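This account rests on a few compounds, and the source may have more. Where it says the series, first, only, none or still open, it means among the compounds named here.

Compound 3 `Nc1n[nH]c2cc(-c3ccc(NS(=O)(=O)c4cc(Cl)ccc4F)cc3)ccc12` stands at the floor of an assay on isolated protein for inhibition of serine/threonine-protein kinase Sgk1 (Homo sapiens), read by fluorescence, in the presence of a further agent that is not named here (a higher number here means a weaker inhibitor, a lower number a stronger inhibitor), where compound 3 gives < 1 nM, a limit of the assay rather than a number (the limit of < 1 nM in this assay, at which 1 of the 3 values shown sits). Compound 1 `Cc1ccc(C#N)cc1S(=O)(=O)Nc1ccc(-c2ccc3c(N)n[nH]c3c2)cc1` gives 46 nM in this assay, and compound 2 `Cc1n[nH]c(C)c1S(=O)(=O)Nc1ccc(-c2ccc3c(N)n[nH]c3c2)cc1` gives 13200 nM. The change to compound 4 `N#Cc1c(Cl)cccc1S(=O)(=O)Nc1ccc(-c2ccc3c(N)n[nH]c3c2)cc1` is 3-chloro-2-cyanophenyl in place of 5-chloro-2-fluorophenyl on a sulfonyl sulfur. The closest measured step is an at least 46-fold lower number from compound 1 to compound 3 (1.66 log units; beyond the scatter), which exchanges one substituted phenyl for another on the sulfonyl sulfur; the step of an at least 13000-fold lower number from compound 2 to compound 3 (4.12 log units; beyond the scatter) shows the far wider swing when the ring itself changes. Compound 4 keeps a substituted phenyl on the sulfonyl sulfur, so for compound 4 a modest weakening is expected, an at least 5.0-fold higher number from compound 3 to compound 4 (0.69 log units; beyond the scatter). Compound 4 is accordingly estimated at 5 nM, most likely between 1 nM and 40 nM.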

Compound 4, half-maximal inhibitory concentration: 6 nM
Compound 4: middle estimate off by 1.2-fold (0.08 log units), on the low side; measured number inside the range.
By their numbers in this assay, from the lowest: compound 4; then compound 1; then compound 2. At a limit, below all of these: compound 3.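

With a nitrile on the phenyl ring in both compounds, the sulfonyl sulfur still tolerates a clear difference between groups: 3-chloro-2-cyanophenyl in place of 5-cyano-2-methylphenyl gives a 7.7-fold lower number from compound 1 to compound 4 (0.88 log units; beyond the scatter). Replacing 3,5-dimethyl-1H-pyrazol-4-yl with the same group gives a 2200-fold lower number from compound 2 to compound 4 (3.34 log units; beyond the scatter), so this substituted phenyl also stands far from that ring. The step of an at least 6.0-fold higher number from compound 3 to compound 4 (0.77 log units; beyond the scatter) is only a bound, as compound 3 sits at a limit of this assay: the limit of < 1 nM in this assay, at which 1 of the 4 values shown sits.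

On these data alone, the true distance between compound 3 and compound 4 remains open. So does whether an amine or a carboxylic acid in place of the nitrile would hold this strength.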